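Pyrazinyl alkyne analogue of a BaF3 antiproliferative series

The source may hold more compounds than are shown below. What is called first, only, known or untested is meant among the compounds shown, and "the series" means these compounds.

Measured so far:
compound 1, `CCN1CCN(Cc2ccc(NC(=O)c3ccc(C)c(C#Cc4ccc(NC(=O)C5CC5)nc4)c3)cc2C(F)(F)F)CC1`, 1800 nM
compound 2, `CCN1CCN(Cc2ccc(NC(=O)c3ccc(C)c(C#Cc4ccc(C(=O)NC)nc4)c3)cc2C(F)(F)F)CC1`, 3980 nM

Two compounds share a core and differ at the far end of the alkyne. In a functional assay on BaF3 cells (Mus musculus) for antiproliferative activity (a lower number here means that less compound is needed, a higher number that more compound is needed for the effect), compound 1 gives 1800 nM, the lowest of the two numbers, and compound 2 gives 3980 nM. Within the data shown here, the one measured step is a 2.2-fold higher number from compound 1 to compound 2 (0.34 log units; beyond the scatter); this is the only guide to how changes at this end of the molecule register in this assay.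

Compound 3, `CCN1CCN(Cc2ccc(NC(=O)c3ccc(C)c(C#Cc4cnccn4)c3)cc2C(F)(F)F)CC1`, has not been measured. It differs from compound 1 by pyrazin-2-yl in place of 6-((cyclopropylcarbonyl)amino)pyridin-3-yl on a triple-bonded carbon. Among the measured compounds shown here, the change is larger than the one between compound 1 and compound 2, since the whole amide-bearing ring is exchanged for a smaller ring carrying nothing. Given that the milder change gave a 2.2-fold higher number from compound 1 to compound 2 (0.34 log units; beyond the scatter), a larger upward step is expected here, a 3.1-fold higher number from compound 1 to compound 3 (0.49 log units; beyond the scatter). Compound 3 is estimated at 5500 nM, within a range from 1800 nM to 17000 nM.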

Compound 3, half-maximal effective concentration: 2490 nM
For compound 3 the middle estimate is 2.2-fold (0.34 log units) above the measured one, within the range that was stated.
By their numbers in this assay, from the lowest: compounds 1, 3 and 2 (each within the scatter of the next, the first and the last beyond it).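

In this assay, replacing the whole 6-((cyclopropylcarbonyl)amino)pyridin-3-yl group with the smaller pyrazin-2-yl gives only a small change (a 1.4-fold higher number from compound 1 to compound 3 (0.14 log units; within the scatter)), so at this triple-bonded carbon the loss of the amide-bearing ring and its three-membered ring does not register beyond the scatter. The comparison with the 6-(methylcarbamoyl)pyridin-3-yl group is also small (a 1.6-fold lower number from compound 2 to compound 3 (0.20 log units; within the scatter)), which places compound 3 within the scatter of both amides even though those two lie apart (a 2.2-fold higher number from compound 1 to compound 2 (0.34 log units; beyond the scatter)), and shows that neither amide is required for a number in this range. Nothing available explains this outcome.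

From the compounds shown here alone, whether any group at this carbon can move the number well beyond this narrow band remains open. An amine or a carboxylic acid on the pyrazin-2-yl ring, for example, would test whether this end of the molecule can register more strongly.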